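The source may report more compounds than this note shows. Statements on the series, on what has been measured and on what is new or still open speak of the compounds shown alone.

Measured compounds:
- compound 2 `COc1ccc(-c2c(C#N)c(N)c(C#N)c(SC)c2-c2ccccc2)cc1`: 37.9%
- compound 3 `COc1ccc(-c2c(C#N)c(N)c(C#N)c(SC)c2-c2ccc(OC)cc2)cc1`: 6.9%
- compound 1 `CSc1c(C#N)c(N)c(C#N)c(-c2ccccc2)c1-c1ccccc1`: "not active" (no number reported)

In an assay on isolated protein for inhibition of glucose-6-phosphatase catalytic subunit 1 (Homo sapiens), tested at 100 uM (on this read-out higher numbers stand for more inhibition at the one concentration tested (going by the name of the read-out) and lower numbers for less inhibition), compound 2 gives 37.9%, the highest of the two numbers recorded; its nearest neighbour is compound 3, and the step of a number 31 percentage points lower from compound 2 to compound 3 (beyond the scatter) goes beyond the scatter. Compound 1 is recorded only as "not active" (no number reported), without a number.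

Compound 4 `CSc1c(C#N)c(N)c(C#N)c(Cc2ccccc2)c1-c1ccccc1` is not yet measured. It differs from compound 2 in one place: benzyl in place of 4-methoxyphenyl on an aromatic carbon. Two pieces of evidence bear on this change. The step of a number 31 percentage points lower from compound 2 to compound 3 (beyond the scatter) shows that adding a methoxy to the second aromatic ring lowered inhibition markedly. Compound 1, which carries no methoxy at all, shows only "not active" (no number reported), so removing the methoxy from compound 2 did not help either. For the measured compounds named here, compound 4 both drops the methoxy and changes the phenyl to a benzyl, a change for which no measured step exists. Given that both neighbours of compound 2 sit lower, compound 4 is expected to sit below compound 2 in this assay, with the step of a number 22.9 percentage points lower from compound 2 to compound 4 (beyond the scatter) expected to be downward and beyond the scatter. The estimate for compound 4 is 15%, with a likely range from 0% to 38%.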

Compound 4, a percentage reported as inhibition, at one concentration (the size of the read-out at that concentration, not a potency): 11.6%
For compound 4 the middle estimate is 3.4 percentage points above the measured one; low and high end bracket the measured number.
By their numbers in this assay, from the lowest: compounds 3 and 4 (each within the scatter of the next); then compound 2.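

In this assay, for the compounds shown here, the benzyl swap gives the first numbered step at this position, ortho to a cyano group and ortho to a phenyl group, since the earlier step concerned only the methoxy on the other aromatic ring: a number 26.3 percentage points lower from compound 2 to compound 4 (beyond the scatter), which lies beyond the scatter and shows that the number seen with the 4-methoxyphenyl group does not survive this change. The step swaps the directly attached aromatic ring for a benzyl and removes the methoxy in one move, so it cannot show which part of the change accounts for the loss. A step to compound 1 , recorded as "not active" (no number reported), cannot be read. That compound has no number. Nothing measured here gives a reason for the lower number.

The compounds shown leave open whether a 4-methoxybenzyl group, which would keep the methoxy on a benzyl, would hold the number of compound 2 or follow compound 4. They also leave open how a longer chain such as phenethyl, or an amine such as morpholine, would read on this aromatic carbon.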